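Replacing a hydroxy group with an aminopropyl chain

This account rests on a few compounds, and the source may have more. Where it says the series, first, only, none or still open, it means among the compounds named here.

Measured so far in a functional assay on the whole organism (Tail, strain ICR) with Mus musculus as the target, in the tail flick test, with a stated time of 30 min, at a dose of 25 umol/kg by the oral route; on this read-out lower numbers stand for a weaker effect and higher numbers for a stronger effect at the one dose given:
compound 1, `O=C(CN(c1nc(Cl)nc2[nH]cnc12)C1CC1)N[C@@H](CO)C(=O)OCc1ccccc1`, gives 31.9%
compound 2, `O=C(O)[C@@H]1CCCN1C(=O)CN(c1nc(Cl)nc2[nH]cnc12)C1CC1`, gives 31.5%
compound 3, `O=C(CN(c1nc(Cl)nc2[nH]cnc12)C1CC1)N[C@@H](CO)C(=O)O`, gives 38.7%

Compound 3 stands highest of these three numbers, but both gaps are within the usual scatter: a number 6.8 percentage points higher from compound 1 to compound 3 (within the scatter) and a number 7.2 percentage points higher from compound 2 to compound 3 (within the scatter). So the three measured compounds cannot be told apart on this read-out.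

Compound 4, `NCCCC[C@H](NC(=O)CN(c1nc(Cl)nc2[nH]cnc12)C1CC1)C(=O)O`, differs from compound 3 in one place: 3-aminopropyl in place of hydroxy on a saturated chain carbon, two bonds along the chain from an amide-type nitrogen and a carbonyl carbon. For the measured compounds named here, no measured step makes this exact change. The closest is the step from compound 2 to compound 3, which exchanged the whole group on the carbonyl carbon and stayed within the scatter; the exchange of benzyl for hydrogen from compound 1 to compound 3 also stayed within the scatter. Both changes in this region of the molecule left the number where it was, so for compound 4 no step beyond the scatter is expected: a number 2.7 percentage points lower from compound 3 to compound 4 (within the scatter). Compound 4 is therefore estimated at 36%, with a range from 24% to 48%.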

Compound 4, a percentage reported as activity, at one dose (the size of the read-out at that dose, not a potency): 31.2%
For compound 4 the middle estimate is 4.8 percentage points above the measured one; the measured number falls inside the stated range.
By their numbers in this assay, from the lowest: compounds 4, 2, 1 and 3 (each within the scatter of the next).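

In this assay, putting 3-aminopropyl in place of hydroxy on this saturated chain carbon gives a number 7.5 percentage points lower from compound 3 to compound 4 (within the scatter), so compound 3 and compound 4 cannot be told apart. The earlier steps shown here changed the benzyl on the oxygen and the whole group on the carbonyl carbon, while this one shows that exchanging a single oxygen-containing group for a chain of 4 heavy atoms with a terminal nitrogen also stays within the scatter at this one dose. Nothing available accounts for this outcome or links it to any property of either group.

From the compounds shown here alone, whether a 3-carboxypropyl or a methyl group in place of hydroxy on this carbon would read differently stays open. Also open, going by these compounds, is whether any group here can produce a step beyond the scatter.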